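Trimming a Phenyl From an Inactive Compound

A few compounds are considered here, and "the series" means these few. Any claim that something is new, unique, unknown or untested is made for them only; others in the source may bear on it.

Compound 1 `CCC(C)C(NC(=O)NO)C(=O)NC(c1ccccc1)c1ccccc1` is measured in a functional assay on HeLa cells (Homo sapiens) for inhibition; on this read-out lower numbers stand for stronger inhibition and higher numbers for weaker inhibition. In this assay compound 1 gives > 100000 nM, a limit of the assay rather than a number (the limit of > 100000 nM in this assay, at which 1 of the 2 values shown sits). Compound 2 `CCC(C)C(NC(=O)n1nnc2ccccc21)C(=O)NC(c1ccccc1)c1ccccc1` gives 60000 nM in this assay, and the step of an at least 1.6-fold lower number from compound 1 to compound 2 (0.22 log units; that floor lies within the scatter) changes the group on the carbonyl carbon, not the diphenylmethyl end. Compound 3 `CCC(C)C(NC(=O)NO)C(=O)NCc1ccccc1` differs from compound 1 by hydrogen in place of phenyl on a saturated chain carbon bound to an amide-type nitrogen and an aromatic carbon. Going by the values given here, no measured step touches that end, so a step of no more than the scatter is expected: a step that the limit leaves unreadable from compound 1 to compound 3. Compound 3 is estimated at 150000 nM, expected between 50000 nM and 500000 nM.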

Compound 3, half-maximal inhibitory concentration: > 100000 nM
Compound 3 ended at the assay's limit (the forecaster's own chance of this, stated with the estimate: 85%); the middle value lies beyond the limit too.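

The values of compound 1 and compound 3 are both limits of the assay, not numbers, and the step between them cannot be read. Going by these compounds, whether hydrogen in place of phenyl changes inhibition at all remains open.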